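This account rests on a few compounds, and the source may have more. Where it says the series, first, only, none or still open, it means among the compounds named here.

In a functional assay on MCF7 cells (Homo sapiens) for inhibition, read by sulforhodamine B assay (a higher number here means a weaker inhibitor, a lower number a stronger inhibitor), three compounds built on a shared core have been measured, and none of them has yet returned a number. Compound 1 (`O=C1C=C(NCc2ccccc2)C(=O)c2c1nc1n2[C@H]2OC[C@@H](O)[C@H]2OC1`) gives > 8000 nM, which is a limit. Compound 2 (`O=C1C(Nc2ccccc2F)=CC(=O)c2c1nc1n2[C@H]2OC[C@@H](O)[C@H]2OC1`) gives > 4000 nM, also a limit. Compound 3 (`O=C1C(Nc2ccccc2)=CC(=O)c2c1nc1n2[C@H]2OC[C@@H](O)[C@H]2OC1`) gives > 4000 nM, again a limit. Compound 3 thus stands at the limit of > 4000 nM in this assay, at which 2 of the 3 values shown sit.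

Compound 4 (`O=C1C(Nc2ccc(Br)cc2)=CC(=O)c2c1nc1n2[C@H]2OC[C@@H](O)[C@H]2OC1`) carries bromo in place of hydrogen on an aromatic carbon of compound 3, para to a large group: bromo in place of hydrogen on an aromatic carbon. Within the data shown here, the one measured step that bears on this change is also a swap on an aromatic carbon, and it is a step that the two limits leave unreadable from compound 2 to compound 3. Among the measured compounds shown here, it therefore offers neither a size nor a direction to carry over, and no definite step in this assay can be expected. Compound 4 is expected to stay close to the limit of compound 3. The estimated change is a step that the limit leaves unreadable from compound 3 to compound 4. Compound 4 is estimated at 5000 nM, with an expected range from 1500 nM to 12000 nM.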

Compound 4, half-maximal inhibitory concentration: 4330 nM
Compound 4: middle estimate off by 1.2-fold (0.06 log units), on the high side; low and high end bracket the measured number.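

Among these compounds, compound 4 returns the only actual number in this assay, while compound 2 and compound 3 stand only as limits, and neither step to compound 4 can be read. The compounds shown leave open whether bromo in place of hydrogen changes inhibition at all.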